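Carbonyl substituent change in a positive allosteric modulator series

This account rests on a few compounds, and the source may have more. Where it says the series, first, only, none or still open, it means among the compounds named here.

Compound 1 `O=C(C1CC12CCC2)N1CCc2nc(C#Cc3ccccc3)sc2C1`: 3.9 nM
Compound 2 `O=C(C1CC(F)(F)C1)N1CCc2nc(C#Cc3cccc(F)c3)sc2C1`: 2.5 nM
Compound 3 `O=S(=O)(C1CCCCC1)N1Cc2nc(C#Cc3ccccc3)sc2C1`: 150 nM

In an assay on HEK293 cells for positive allosteric modulation of metabotropic glutamate receptor 5 (Homo sapiens), read by FLIPR, with a stated time of 1 h (on this read-out lower numbers stand for an effect already at smaller amounts and higher numbers for an effect only at larger amounts of compound), compound 1 gives 3.9 nM, the second highest of the three numbers. Compound 2 gives 2.5 nM, which lies within the scatter of compound 1. Compound 3 gives 150 nM, a gap from compound 1 that is beyond the scatter. Among the compounds with values here, no two measured compounds differ in one place only, so no measured step bears directly on the change considered here.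

Compound 4 `O=C(N1CCC(F)CC1)N1CCc2nc(C#Cc3ccccc3)sc2C1` differs from compound 1 as follows: a group of 7 heavy atoms (5 carbon, 1 nitrogen, 1 fluorine; one six-membered non-aromatic ring with 1 hetero atom) in place of a group of 6 heavy atoms (6 carbon; one three-membered non-aromatic ring of carbon only, one four-membered non-aromatic ring of carbon only), on a carbonyl carbon. Within the data shown here, with no precedent, a moderate rise in the number is expected for the step of a 3.1-fold higher number from compound 1 to compound 4 (0.49 log units; beyond the scatter), larger than the scatter but far short of the gap to compound 3. Compound 4 is estimated at 12 nM, with a range from 2.5 nM to 60 nM.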

Compound 4, half-maximal effective concentration: 74 nM
The estimate for compound 4 lay 6.2-fold (0.79 log units) below the measured number; measured number above the stated range.
By their numbers in this assay, from the lowest: compounds 2 and 1 (each within the scatter of the next); then compound 4; then compound 3.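

In this assay, 4-fluoropiperidin-1-yl in place of the all-carbon ring group on the carbonyl carbon gives a 19-fold higher number from compound 1 to compound 4 (1.28 log units; beyond the scatter). Within the data shown here, this is the first single-place step, and it shows that the group on this carbonyl carbon alone can produce a large change while the rest of the molecule stays the same. No measurement at hand explains the step.

The ring nitrogen and the fluorine enter together, so the step cannot be divided between them. Unsubstituted piperidin-1-yl and cyclohexyl on the same carbonyl carbon would separate the two.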